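Rearranging a pendant group and the expected cytotoxicity of compound 4

The source may report more compounds than this note shows. Statements on the series, on what has been measured and on what is new or still open speak of the compounds shown alone.

Compound 1 `CC1(Cc2ccccc2)CC(S(=O)(=O)c2cccc(F)c2)=C(c2ccc(/C(N)=N\O)cc2)O1`: 59600 nM
Compound 2 `CC1(c2ccc(-c3ccc(/C(N)=N\O)cc3)cc2)CC(S(=O)(=O)c2ccc(F)cc2)=C(c2ccc(/C(N)=N\O)cc2)O1`: 15300 nM
Compound 3 `CC1(Cc2ccccc2)CC(S(=O)(=O)c2ccc(F)cc2F)=C(c2ccc(/C(N)=N\O)cc2)O1`: 90600 nM

All three were measured in an ADME assay on HepG2 cells (Homo sapiens) for cytotoxicity, read by MTT assay, with a stated time of 72 h; on this read-out lower numbers stand for higher toxicity in this test and higher numbers for lower toxicity in this test. Compound 2 gives the lowest of the three numbers; compound 1 stands nearest and compound 3 furthest, both beyond the scatter. For the measured compounds named here, the only measured step between single-change neighbours is a 1.5-fold higher number from compound 1 to compound 3 (0.18 log units; within the scatter), a change on the sulfonyl sulfur that leaves the part altered here untouched. Compound 4 `CC1(c2ccc(-c3cccc(/C(N)=N\O)c3)cc2)CC(S(=O)(=O)c2ccc(F)cc2)=C(c2ccc(/C(N)=N\O)cc2)O1` differs from compound 2 by a group of 10 heavy atoms (7 carbon, 2 nitrogen, 1 oxygen; one six-membered aromatic ring of carbon only) in place of a group of 10 heavy atoms (7 carbon, 2 nitrogen, 1 oxygen; one six-membered aromatic ring of carbon only), on an aromatic carbon, on an aromatic carbon of a six-membered aromatic ring of carbon only, para to a large group. Going by the values given here, no measured step bears on this rearrangement, so no shift beyond the scatter is expected in this assay. Compound 4 is therefore estimated at 18000 nM, within 7000 nM to 45000 nM. The step this estimate means is a 1.2-fold higher number from compound 2 to compound 4 (0.07 log units; within the scatter).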

Compound 4, half-maximal cytotoxic concentration: 19000 nM
For compound 4 the middle estimate is 1.1-fold (0.02 log units) below the measured one; the range from low to high includes it.
By their numbers in this assay, from the lowest: compounds 2 and 4 (each within the scatter of the next); then compounds 1 and 3 (each within the scatter of the next).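

In this assay the pendant group of compound 2 and that of compound 4 hold the same atoms joined differently, and the step is a 1.2-fold higher number from compound 2 to compound 4 (0.09 log units; within the scatter), which stays within the scatter. This is the first step shown at this place, on an aromatic carbon para to a large group, and it shows that this rearrangement alone does not take the number beyond the scatter. No evidence here explains the result.

As far as these compounds go, whether a carboxylic acid or an amine in this place would give a different number remains open.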